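A few compounds are considered here, and "the series" means these few. Any claim that something is new, unique, unknown or untested is made for them only; others in the source may bear on it.

Compound 1 `CN(C)CCC(=O)Nc1cccc(-c2nc3ccccc3s2)c1` and compound 2 `O=C(CCl)Nc1cccc(-c2nc3ccccc3s2)c1` share one core. In an ADME assay on BJ cells (Homo sapiens) for inhibition, with a stated time of 72 h (a higher number here means that more compound is needed for the effect, a lower number that less compound is needed), compound 1 reaches only a limit of the assay, > 25000 nM (the limit of > 25000 nM in this assay, at which 1 of the 2 values shown sits). Compound 2 gives 8500 nM, the only number shown in this assay. Within the data shown here, the sole measured step, an at least 2.9-fold lower number from compound 1 to compound 2 (0.46 log units; beyond the scatter), concerns the chain carbon and not the carbonyl carbon. Compound 3 `O=C(Nc1cccc(-c2nc3ccccc3s2)c1)c1cccnc1Cl` differs from compound 2 by 2-chloropyridin-3-yl in place of chloromethyl on a carbonyl carbon. Among the measured compounds shown here, no measured step touches this position, so compound 3 is expected to show a step of a 1.2-fold lower number from compound 2 to compound 3 (0.08 log units; within the scatter), within the scatter. Compound 3 is estimated at 7000 nM, between 1800 nM and 25000 nM.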

Compound 3, half-maximal effective concentration: > 25000 nM
Compound 3 ended at the assay's limit; the forecaster's own chance of this, stated with the estimate: 25%; middle value at least 3.5-fold (0.55 log units) from the limit.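

Among these compounds, on the carbonyl carbon, 2-chloropyridin-3-yl in place of chloromethyl gives an at least 2.9-fold higher number from compound 2 to compound 3 (0.46 log units; beyond the scatter) in this assay, the only readable step at this position. Compound 3 gives > 25000 nM, which is a limit of the assay. The step between compound 1 and compound 3 cannot be read, and limits now make up most of what the series shows: the limit of > 25000 nM in this assay, at which 2 of the 3 values shown sit.

As far as these compounds go, whether a plain methyl, a bromomethyl or a longer chain on the carbonyl carbon would give a number in this assay stays open. Also open, from the compounds shown here alone, is whether the chlorine of chloromethyl matters, or the small size of that group.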